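The compounds below may be only part of what the source reports. "The series", "measured", "known", "first", "only" and "open" are said of these compounds alone.

Working notes on the butenolide series.

The shared core of compound 1 `O=C1O[C@H]([C@@H](O)Cn2cc(CNS(=O)(=O)c3ccc(Cl)cc3F)nn2)C(OCc2ccccc2)=C1OCc1ccccc1` carries a triazole substituent. Compound 2 `O=C1O[C@H]([C@@H](O)Cn2cc(CCO)nn2)C(OCc2ccccc2)=C1OCc1ccccc1` and compound 3 `O=C1O/C(=C\Cn2cc(-c3cccc(O)c3)nn2)C(OCc2ccccc2)=C1OCc1ccccc1` vary that substituent. In a functional assay on HCT-116 cells (Homo sapiens) for antiproliferative activity, read by MTT assay, with a stated time of 72 h (on this read-out higher numbers stand for weaker inhibition and lower numbers for stronger inhibition), compound 1 gives 21600 nM, compound 2 gives 72700 nM and compound 3 gives 63600 nM. Compound 2 thus shows the highest number of the three, with compound 3 within the scatter of it and compound 1 set apart by a 3.4-fold higher number from compound 1 to compound 2 (0.53 log units; beyond the scatter).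

Compound 4 `O=C1O[C@H]([C@@H](O)Cn2ccnn2)C(OCc2ccccc2)=C1OCc1ccccc1` is the next step from compound 2: hydrogen in place of 2-hydroxyethyl on an aromatic carbon. Within the data shown here, only one measured step bears on the substituent on this ring carbon, a 3.4-fold higher number from compound 1 to compound 2 (0.53 log units; beyond the scatter), which ran from a large sulfonamide-bearing group to a short hydroxyl-bearing chain and raised the number by a modest amount. Compound 4 drops the chain altogether, so the same direction is expected: the number of compound 4 is expected to sit at or somewhat above that of compound 2, with a 1.3-fold higher number from compound 2 to compound 4 (0.12 log units; within the scatter) as the expected step, most likely within or just beyond the scatter. Compound 4 is therefore estimated at 95000 nM in this assay, with a plausible range from 40000 nM to 220000 nM; there is a real chance the assay returns only a limit at this level.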

Compound 4, half-maximal inhibitory concentration: > 100000 nM
Compound 4 gave a limit, no number; the forecaster's own chance of this, stated with the estimate: 25%; middle value at least 1.0-fold (0.02 log units) away from the limit.
By their numbers in this assay, from the lowest: compound 1; then compounds 3 and 2 (each within the scatter of the next). At a limit, above all of these: compound 4.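

Compound 4 reads only as a limit in this assay: the limit of > 100000 nM in this assay, at which 1 of the 4 values shown sits. From the compounds shown here alone, with hydrogen in place of 2-hydroxyethyl on this aromatic carbon, the step is an at least 1.3-fold higher number from compound 2 to compound 4 (0.13 log units; that floor lies within the scatter), so the floor of this change stays within the scatter and its true size remains unknown. The earlier step compared two substituted compounds, whereas this one adds the unsubstituted end of the position, where the assay returns no number; the pair alone cannot show whether removing the chain has any effect beyond the scatter.

Going by these compounds, it remains open whether an amine, a carboxylic acid or a longer chain on this aromatic carbon would bring the number closer to that of compound 1, at 21600 nM, and whether the sulfonamide nitrogen or the aryl ring in that compound's substituent accounts for its separation from compound 2. Compound 3 differs from compound 2 in more than one place, so its 3-hydroxyphenyl group cannot be read as a single change at this position.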